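Adding one methyl to compound 3: what to expect

The source may hold more compounds than are shown below. What is called first, only, known or untested is meant among the compounds shown, and "the series" means these compounds.

compound 1 `Cc1nc2cc(Cl)c(Cl)cc2[nH]1` gives 28000 nM
compound 2 `FC(F)(F)c1nc2cc(Cl)c(Cl)cc2n1CC1CC1` gives 60200 nM
compound 3 `Clc1cc2ncn(C3CCCC3)c2cc1Cl` gives 42000 nM

In a functional assay on MCF7 cells (Homo sapiens) for cytotoxicity, read by MTT assay, with a stated time of 48 h (a lower number here means a stronger inhibitor of growth, a higher number a weaker inhibitor of growth), compound 3 gives 42000 nM and sits within the scatter of both compound 1 and compound 2. Scatter here means the ordinary spread between repeated measurements, so these three numbers cannot be told apart.

The next compound, compound 4 `Cc1nc2cc(Cl)c(Cl)cc2n1C1CCCC1`, keeps the cyclopentyl group of compound 3 and has methyl in place of hydrogen on an aromatic carbon, between two ring nitrogen atoms methyl in place of hydrogen on an aromatic carbon in counted terms.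

Within the data shown here, no measured pair of compounds differs in only one place, so the size of this step cannot be read directly. There are only indirect hints. Compound 1 already carries a methyl on that carbon and gives 28000 nM in this assay while compound 2 carries a trifluoromethyl there and gives 60200 nM in the same test. Neither value is separated from that of compound 3, which has hydrogen there. No shift beyond the scatter is therefore expected, in either direction.

The estimated change is a 1.1-fold lower number from compound 3 to compound 4 (0.04 log units; within the scatter) and it is expected to stay within the scatter. Compound 4 is estimated at 38000 nM and is expected to fall from 18000 nM to 80000 nM in most repeat measurements.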

Compound 4, concentration for 50% growth inhibition: 40000 nM
The estimate for compound 4 lay 1.1-fold (0.02 log units) below the measured number, within the range that was stated.
By their numbers in this assay, from the lowest: compounds 1, 4, 3 and 2 (each within the scatter of the next, the first and the last beyond it).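

Among these compounds, compound 3 and compound 4 form the first pair that differs in one place only, so the methyl step can now be read directly: in this assay methyl in place of hydrogen on this aromatic carbon gives a 1.1-fold lower number from compound 3 to compound 4 (0.02 log units; within the scatter) and so leaves no measurable mark at this position, between two ring nitrogen atoms and next to the ring atom that bears a cyclopentyl group. Compound 4 also gives a second one-place pair, in which cyclopentyl in place of hydrogen on an aromatic nitrogen gives a 1.4-fold higher number from compound 1 to compound 4 (0.15 log units; within the scatter) and, with methyl on the carbon, likewise cannot be told from the scatter. Nothing available here offers an explanation for either result.

Compound 2 differs from the other compounds in more than one place, so its steps cannot be read, and trifluoromethyl on this carbon has no one-place comparison of its own. Going by these compounds, whether an amine, a carboxylic acid or a longer chain on the same carbon would move the number beyond the scatter remains open.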